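Nitro to methoxy on the hydroxyphenyl dienone series

The source may report more compounds than this note shows. Statements on the series, on what has been measured and on what is new or still open speak of the compounds shown alone.

Measured compounds in an in vitro assay on cells for inhibition of Amine oxidase [flavin-containing] A (Homo sapiens), read by Amplex Red, with a stated time of 15 min, tested at 100 uM; on this read-out higher numbers stand for more inhibition at the one concentration tested (going by the name of the read-out) and lower numbers for less inhibition:
compound 1, `O=C(/C=C(O)/C=C/c1ccc([N+](=O)[O-])cc1)c1ccccc1O`, "not active" (no number reported)
compound 2, `COc1ccc(/C=C/C=C/C(=O)c2ccccc2O)cc1OC`, 40%
compound 3, `O=C(/C=C/C=C/c1ccc([N+](=O)[O-])cc1)c1cc(Cl)ccc1O`, "not active" (no number reported)

Compound 1 has no single number in this assay; its result is reported only as inactive, and compound 3 is a second entry of the same kind, so no ordering of compound 1 against any other compound can be drawn. Compound 2, the only entry with a figure, gives 40% in this assay. Both nitro-bearing compounds lack a number, whereas the entry carrying methoxy groups is the one that returns a figure; with three compounds this is an observation, not a pattern.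

Compound 4, `COc1ccc(/C=C/C(O)=C/C(=O)c2ccccc2O)cc1`, is not yet measured. The change from compound 1 is methoxy in place of nitro on an aromatic carbon. Among the measured compounds shown here, no measured pair in the set mirrors this step, so its size is not known; given that compound 1 is reported inactive while compound 2 gives 40%, a move towards measurable inhibition is expected rather than none. For compound 4 the expected read-out in this assay is 30%, with a range from 5% to 55%.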

Compound 4, a percentage reported as inhibition, at one concentration (the size of the read-out at that concentration, not a potency): "not active" (no number reported)
For compound 4 the study gives words and no number, so the estimate cannot be set against anything.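

In this assay, among the compounds shown here, compound 1 and compound 4 are both reported in words only, so no step between them can be read. Nothing shown bears on why. The compounds shown leave open whether methoxy in place of nitro changes inhibition at all on this core.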